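This account rests on a few compounds, and the source may have more. Where it says the series, first, only, none or still open, it means among the compounds named here.

Measured so far:
compound 1 `Nc1nn(C(=O)Nc2ccc(Cc3ccccc3)cc2)c2ccccc12`, 92700 nM in a functional assay on 786-0 cells (Homo sapiens) for antiproliferative activity, read by sulforhodamine B assay, with a stated time of 48 h; a lower number here means that less compound is tolerated, a higher number that more compound is tolerated
compound 2 `Nc1nn(C(=O)Nc2ccc(Cc3ccccc3)cc2)c2ccc(Cl)cc12`, 94400 nM

Compound 2 stands with the higher of these two numbers, and its nearest neighbour is compound 1: the step of a 1.0-fold higher number from compound 1 to compound 2 (0.01 log units; within the scatter) lies within the scatter, so the two compounds are not distinguishable. Compound 3 `Nc1ccc2c(c1)c(N)nn2C(=O)Nc1ccc(Cc2ccccc2)cc1` is the next step, with amino in place of chloro on an aromatic carbon. Among the measured compounds shown here, the only measured step, from compound 1 to compound 2, bears on the same carbon and changed nothing beyond the scatter, so little change is expected in this assay from compound 2 to compound 3 either. Compound 3 is therefore estimated at 90000 nM, between 40000 nM and 200000 nM, a step of a 1.0-fold lower number from compound 2 to compound 3 (0.02 log units; within the scatter) that is expected to stay within the scatter.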

Compound 3, concentration lethal to 50% of the cells: 54300 nM
Estimate against measurement, compound 3: 1.7-fold (0.22 log units) above; the measured number falls inside the stated range.
By their numbers in this assay, from the lowest: compounds 3, 1 and 2 (each within the scatter of the next).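

In this assay amino in place of chloro gives a 1.7-fold lower number from compound 2 to compound 3 (0.24 log units; within the scatter) and amino in place of hydrogen gives a 1.7-fold lower number from compound 1 to compound 3 (0.23 log units; within the scatter) on the same aromatic carbon. Hydrogen, chloro and amino at this position therefore cannot be told apart, even though amino carries a hydrogen-bond donor and acceptor and chloro carries none. No measurement is available that could explain this result. Still open, on these data alone, is whether a different group on this carbon, such as a carboxylic acid or a methoxy, would move the number beyond the scatter.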